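Notes on the arylamide series: nitro for trifluoromethyl

The compounds below may be only part of what the source reports. "The series", "measured", "known", "first", "only" and "open" are said of these compounds alone.

Compound 1 `COc1ccc(C(=O)c2cc(OC)c(OC)c(OC)c2)cc1NC(=O)/C=C/c1ccc(OC)c(OC)c1` carries 3,4-dimethoxyphenyl on the double-bonded chain; in a functional assay on B16 cells (Mus musculus) for cytotoxicity, read by MTT assay, with a stated time of 72 h (a lower number here means a stronger inhibitor, a higher number a weaker inhibitor), compound 1 gives 6300 nM. Compound 2 `COc1ccc(C(=O)c2cc(OC)c(OC)c(OC)c2)cc1NC(=O)/C=C/c1ccc(C(F)(F)F)cc1` differs only in bearing 4-(trifluoromethyl)phenyl at that position, and in this assay compound 2 gives 100 nM. Within the data shown here, the single step measured so far is a 63-fold lower number from compound 1 to compound 2 (1.80 log units; beyond the scatter), and compound 2 holds the lower of the two numbers by that same margin. Compound 3 `COc1ccc(C(=O)c2cc(OC)c(OC)c(OC)c2)cc1NC(=O)/C=C/c1ccc([N+](=O)[O-])cc1` is the next member: nitro in place of trifluoromethyl on an aromatic carbon. Among the measured compounds shown here, no measured pair sets nitro against trifluoromethyl, so the one known step bears on this change only in showing that what sits on this ring can move the number a great deal. For the measured compounds named here, with no closer precedent, the expected step for compound 3 is a 1.5-fold higher number from compound 2 to compound 3 (0.18 log units; within the scatter), essentially no shift. Compound 3 is thus estimated at 150 nM in this assay, with a range from 30 nM to 800 nM wide enough to allow a sizeable move in either direction.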

Compound 3, half-maximal inhibitory concentration: 6400 nM
For compound 3 the middle estimate is 43-fold (1.63 log units) below the measured one; the measured number lies above the stated range.
By their numbers in this assay, from the lowest: compound 2; then compounds 1 and 3 (each within the scatter of the next).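

Nitro in place of trifluoromethyl on the aromatic carbon para to a large group is a large step in this assay (a 64-fold higher number from compound 2 to compound 3 (1.81 log units; beyond the scatter)), so in this pair the low number goes with trifluoromethyl and does not survive this single exchange. 4-Nitrophenyl in place of 3,4-dimethoxyphenyl gives a 1.0-fold higher number from compound 1 to compound 3 (0.01 log units; within the scatter), which leaves two differently substituted rings within the scatter of each other, and among the three compounds only compound 2 stands apart from the rest. Nothing shown accounts for the gap between trifluoromethyl and nitro at this position.

Going by these compounds, whether the low number of compound 2 is particular to trifluoromethyl or would also appear with chlorine, a methyl group, an amine or a carboxylic acid on this aromatic carbon stays open. Also open, on these data alone, is whether the same gap between trifluoromethyl and nitro would hold with a longer chain in place of the double-bonded chain, since all three compounds share that chain and the rest of the core.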